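The source may hold more compounds than are shown below. What is called first, only, known or untested is meant among the compounds shown, and "the series" means these compounds.

Measured so far:
compound 1, `CC1=C(/C=C/C(=O)/C=C/c2ccc(Cl)cc2)C(C)(C)CCC1`: 10200 nM
compound 2, `CC1=C(/C=C/C(=O)/C=C/c2ccccc2C)C(C)(C)CCC1`: 44600 nM

Both numbers come from a functional assay on MCF7 cells (Homo sapiens) for cytotoxicity, read by sulforhodamine B assay, with a stated time of 48 h; a higher number here means a weaker inhibitor, a lower number a stronger inhibitor. Among the measured compounds shown here, of the two, compound 2 gives the higher number, and the single step between them, a 4.4-fold higher number from compound 1 to compound 2 (0.64 log units; beyond the scatter), shows that swapping the aromatic ring on the double-bonded chain carbon can move the read-out beyond the scatter. Compound 3, `CC1=C(/C=C/C(=O)/C=C/c2ccoc2)C(C)(C)CCC1`, has not yet been measured. It differs from compound 2 in one place: furan-3-yl in place of 2-methylphenyl on a double-bonded chain carbon bound to a double-bonded chain carbon. For the measured compounds named here, no measured step tests this exact change; the step from compound 1 to compound 2 is the only guide, and it shows a modest shift when that ring is swapped. A shift of similar size in either direction cannot be excluded, so the expectation is wide. Compound 3 is expected to give 25000 nM, within 6000 nM to 80000 nM. This estimate means an expected step of a 1.8-fold lower number from compound 2 to compound 3 (0.25 log units; within the scatter), not beyond the scatter.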

Compound 3, half-maximal inhibitory concentration: 100000 nM
Compound 3: the middle estimate sits 4.0-fold (0.60 log units) below what was measured; the whole stated range lies below it.
By their numbers in this assay, from the lowest: compound 1; then compound 2; then compound 3.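

Furan-3-yl in place of 2-methylphenyl gives a 2.2-fold higher number from compound 2 to compound 3 (0.35 log units; beyond the scatter) in this assay, so this position responds to a change of the ring itself, and not only to a change of the group on a phenyl ring. Measured against 4-chlorophenyl, the same furan-3-yl gives a 9.8-fold higher number from compound 1 to compound 3 (0.99 log units; beyond the scatter), the largest step in the set, which makes compound 3 the weakest of the three in this cell test. Nothing at hand explains this order.

Furan-3-yl differs from both phenyl groups in ring size and in carrying an oxygen, so the compounds shown cannot separate these two changes. An unsubstituted phenyl, a thiophen-3-yl or a pyridine ring at this place would help to tell them apart.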